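The source may hold more compounds than are shown below. What is called first, only, known or untested is meant among the compounds shown, and "the series" means these compounds.

In a functional assay on SF-268 cells (Homo sapiens) for inhibition (on this read-out lower numbers stand for stronger inhibition of growth and higher numbers for weaker inhibition of growth), compound 2 `COc1ccc(-c2cn(-c3cccc(C(=O)/C=C/c4ccc(O)c(OC)c4)c3)c(=O)[nH]2)cc1` gives 3400 nM, and compound 1 `COc1cc(/C=C/C(=O)c2cccc(-n3cc(-c4ccc(Cl)cc4)[nH]c3=O)c2)cc(OC)c1OC` gives 5070 nM, so the two sit within the usual scatter of each other and neither can be set apart. Compound 3 `COc1ccc(-c2cn(-c3cccc(C(=O)/C=C/c4cc(OC)c(OC)c(OC)c4)c3)c(=O)[nH]2)cc1` has not been measured; it carries 3,4,5-trimethoxyphenyl in place of 4-hydroxy-3-methoxyphenyl on a double-bonded chain carbon bound to a double-bonded chain carbon. For the measured compounds named here, compound 1 also bears the trimethoxy group, though it differs from compound 2 in a second place as well, so no single step is known. From compound 2 the step of a 1.3-fold higher number from compound 2 to compound 3 (0.12 log units; within the scatter) is expected to stay within the scatter in this assay. Compound 3 is therefore estimated at 4500 nM, with a range from 1500 nM to 14000 nM.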

Compound 3, concentration for 50% growth inhibition: 3210 nM
Compound 3: middle estimate off by 1.4-fold (0.15 log units), on the high side; the measured number falls inside the stated range.
By their numbers in this assay, from the lowest: compounds 3, 2 and 1 (each within the scatter of the next).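

In this assay, the step of a 1.1-fold lower number from compound 2 to compound 3 (0.02 log units; within the scatter) lies within the scatter, so 3,4,5-trimethoxyphenyl and 4-hydroxy-3-methoxyphenyl cannot be told apart at this chain carbon. For the compounds shown here, the step of a 1.6-fold lower number from compound 1 to compound 3 (0.20 log units; within the scatter) also lies within the scatter, giving the first single-place reading for methoxy in place of chloro on an aromatic carbon. No supporting data explain either result. As far as these compounds go, whether an amine or a carboxylic acid at either place would give a number beyond the scatter stays open.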